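A few compounds are considered here, and "the series" means these few. Any claim that something is new, unique, unknown or untested is made for them only; others in the source may bear on it.

Measured in a physicochemical assay for lipophilicity; a higher number here means a more lipophilic compound, a lower number a more polar compound:
- Compound 1 `O=C(c1nc2c(C(F)(F)F)cc(C3CC3)cn2c1Cl)N1CCN([C@H]2CC[C@H](O)CC2)C(=O)C1`: 3.5
- Compound 2 `O=C(c1nn2c(C(F)(F)F)cc(C3CC3)cc2c1Cl)N1CCN([C@H]2CC[C@H](O)CC2)C(=O)C1`: 4.1

Of the two, compound 2 stands highest at 4.1, and compound 1 gives 3.5. The gap between the two lies beyond the scatter.

Compound 3 `O=C(c1nn2c(C(F)(F)F)cc(C3CC3)cc2c1Cl)N1CCN([C@@H]2C[C@H]3C[C@H]3C2)C(=O)C1` differs from compound 2 in one group, on an amide-type nitrogen in a ring: a group of 6 heavy atoms (6 carbon; one three-membered non-aromatic ring of carbon only, one five-membered non-aromatic ring of carbon only) in place of a group of 7 heavy atoms (6 carbon, 1 oxygen; one six-membered non-aromatic ring of carbon only), on an amide-type nitrogen in a ring. The 4-hydroxycyclohexyl group leaves, and the entering group has 0 hydrogen-bond donors. Among the compounds with values here, no measured step covers this change, so the expectation rests on the structures alone: a rise in this assay, beyond the scatter. The expected size is a number 0.80 log units higher from compound 2 to compound 3 (beyond the scatter). Compound 3 is estimated at 4.9, with an expected range of 4.5 to 5.4.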

Compound 3, distribution coefficient: 6.4
Compound 3: middle estimate off by 1.50 log units, on the low side; the whole stated range lies below it.
By their numbers in this assay, from the lowest: compound 1; then compound 2; then compound 3.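

At the amide-type nitrogen in a ring, the substituent has a large influence on this assay: putting the carbon-only group with a three-membered and a five-membered ring in place of 4-hydroxycyclohexyl gives a number 2.30 log units higher from compound 2 to compound 3 (beyond the scatter). This single step changes the ring system and removes the hydrogen-bond donor and acceptor together, so their shares cannot be separated. Nothing available bears on the origin of the step.

Still open, on these data alone, is how an unsubstituted cyclohexyl or a 4-methoxycyclohexyl group would read at this nitrogen. Also open, as far as these compounds go, is whether the same exchange on the core of compound 1 gives a step of similar size.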